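Toward a Hydrazide Replacement on a Shared Core

A few compounds are considered here, and "the series" means these few. Any claim that something is new, unique, unknown or untested is made for them only; others in the source may bear on it.

Of the compounds shown here, two with the same core have been tested in a toxicity assay on HepG2 cells (Homo sapiens) for inhibition, read by CellTiter-Glo, with a stated time of 48 h; a higher number here means a weaker inhibitor, a lower number a stronger inhibitor. Compound 1 `Cc1cc(C)cc(NC(=O)COc2cc(C)nc3ccccc23)c1` gives > 100000 nM, which is a limit of the assay and not a number. Compound 2 `COc1cccc(NC(=O)COc2cc(C)nc3ccc(OC)cc23)c1` gives > 100000 nM, likewise only a limit. So compound 2 stands at the limit, and the limit of > 100000 nM in this assay, at which 2 of the 2 values shown sit, shows that both values shown sit there.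

Compound 3 `COc1ccc2nc(C)cc(OCC(=O)NNC(=O)c3ccncc3)c2c1` has not yet been tested in this assay. It differs from compound 2 in one place: ((pyridin-4-yl)carbonyl)amino in place of 3-methoxyphenyl on an amide-type nitrogen. Among the measured compounds shown here, no step between measured compounds is known here, so the size of the change cannot be read from earlier pairs. With compound 2 at > 100000 nM, compound 3 is expected to stay near the same limit, a step of a number no higher from compound 2 to compound 3 (the limit leaves the size open), with little reason to expect movement beyond the scatter. The estimate for compound 3 is 100000 nM, between 30000 nM and 300000 nM.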

Compound 3, half-maximal inhibitory concentration: > 100000 nM
Compound 3 gave a limit, no number; the forecaster's own chance of this, stated with the estimate: 80%; the middle value sits exactly at the limit.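

Among the compounds shown here, compound 2 and compound 3 both sit at a limit of the assay and not at a number, so no step between them can be read. The compounds shown leave open how any of them would rank in this assay, because none gives a number: the limit of > 100000 nM in this assay, at which 3 of the 3 values shown sit.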